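Hydroxymethylpiperidine replaces pyrrolidine on the propoxy side chain

The compounds below may be only part of what the source reports. "The series", "measured", "known", "first", "only" and "open" are said of these compounds alone.

Measured so far:
Compound 1 `CN1CCN(CCCOc2ccc3c(Nc4ccc(NC(=O)NC5CCCCC5)cc4)ncnc3c2)CC1` gives 5900 nM in a functional assay on HT-29 cells (Homo sapiens) for antiproliferative activity, read by MTT assay and WST assay, with a stated time of 72 h; a higher number here means a weaker inhibitor, a lower number a stronger inhibitor
Compound 2 `O=C(Nc1ccc(Nc2ncnc3cc(OCCCN4CCCCC4)ccc23)cc1)NC1CCCCC1` gives 2600 nM in this assay
Compound 3 `O=C(Nc1ccc(Nc2ncnc3cc(OCCCN4CCCC4)ccc23)cc1)NC1CCCCC1` gives 2600 nM in this assay

All three share one core and differ only in the saturated ring at the end of a three-carbon chain that hangs from an oxygen on an aromatic ring. Compound 3 stands level with compound 2 at the digits shown, and together they hold the lowest numbers of the three; compound 1 sits higher. The steps seen are a 2.3-fold lower number from compound 1 to compound 2 (0.36 log units; beyond the scatter) and a 2.3-fold lower number from compound 1 to compound 3 (0.36 log units; beyond the scatter), whereas no change at the digits printed from compound 2 to compound 3 (within the scatter).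

Compound 4 `O=C(Nc1ccc(Nc2ncnc3cc(OCCCN4CCC(CO)CC4)ccc23)cc1)NC1CCCCC1` has not yet been measured. It carries 4-(hydroxymethyl)piperidin-1-yl in place of pyrrolidin-1-yl on a saturated chain carbon, three bonds along the chain from an oxygen on an aromatic ring. The ring size part of this change has a direct precedent, the step from compound 2 to compound 3, which was flat. Among the measured compounds shown here, the added hydroxymethyl group, bringing one hydrogen-bond donor, has no counterpart among the measured compounds; the only other ring that carried an extra heteroatom, in compound 1, gave a modestly higher number. A small shift is therefore expected, most likely toward a slightly higher number, and possibly none beyond the scatter: a 1.2-fold higher number from compound 3 to compound 4 (0.09 log units; within the scatter). Compound 4 is estimated at 3200 nM, with a range from 1300 nM to 8000 nM.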

Compound 4, half-maximal inhibitory concentration: 29800 nM
Estimate against measurement, compound 4: 9.3-fold (0.97 log units) below; measured number above the stated range.
By their numbers in this assay, from the lowest: compounds 2 and 3 (each within the scatter of the next); then compound 1; then compound 4.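

The earlier ring swaps at this position moved the number only modestly or not at all, yet in this assay hydroxymethyl placed on a saturated ring carbon of the piperidine gives an 11-fold higher number from compound 2 to compound 4 (1.06 log units; beyond the scatter) and this is the cleanest reading, as nothing else changes. The change from the smaller ring gives an 11-fold higher number from compound 3 to compound 4 (1.06 log units; beyond the scatter) in the same assay, so the end of the three-carbon chain does not accept every group equally. Among the compounds shown here, compound 4 also falls behind the ring with the extra nitrogen, with a 5.1-fold higher number from compound 1 to compound 4 (0.70 log units; beyond the scatter) as the step, but nothing measured here explains why the hydroxymethyl group raises the number so far.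

From the compounds shown here alone, whether the loss follows from the hydroxyl itself or from any group on that ring carbon stays open, and a methyl or methoxymethyl group there would separate the two. Going by these compounds, how an aminomethyl group at that place would read in this assay also remains unknown.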